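A few compounds are considered here, and "the series" means these few. Any claim that something is new, unique, unknown or untested is made for them only; others in the source may bear on it.

Working notes on the series. For the measured compounds named here, compound 1 `COc1ccc(-c2cc(/C=C/C(=O)c3ccc(N)cc3)[nH]n2)cc1` is the only member with a number in a functional assay on M14 cells (Homo sapiens) for inhibition, read by sulforhodamine B assay, with a stated time of 48 h; a higher number here means a weaker inhibitor of growth, a lower number a stronger inhibitor of growth: in that assay compound 1 gives 6540 nM. Compound 2 `COc1cc(-c2cc(/C=C/C(=O)c3ccc(Cl)c(Cl)c3)[nH]n2)cc(OC)c1OC` gives in this assay a limit and not a number, > 100000 nM, which is the limit of > 100000 nM in this assay, at which 1 of the 2 values shown sits. Compound 3 `COc1ccc(-c2cc(/C=C/C(=O)c3ccc(N)cc3)[nH]n2)cc1OC` is not yet measured; it differs from compound 1 by methoxy in place of hydrogen on an aromatic carbon. Going by the values given here, no measured pair isolates this change, so the step from compound 1 to compound 3 is expected to be modest, a slight weakening at most, a 1.4-fold higher number from compound 1 to compound 3 (0.14 log units; within the scatter). Compound 3 is estimated at 9000 nM, with a range from 3000 nM to 30000 nM.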

Compound 3, concentration for total growth inhibition: 5110 nM
Estimate against measurement, compound 3: 1.8-fold (0.25 log units) above; low and high end bracket the measured number.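

In this assay, methoxy in place of hydrogen on an aromatic carbon, ortho to a methoxy group and meta to a large group, gives a 1.3-fold lower number from compound 1 to compound 3 (0.11 log units; within the scatter). For the compounds shown here, this is the first pair to isolate one change, and it shows that this position accepts a methoxy group with no shift beyond the scatter. No measurement at hand bears on the reason for this step. Still open, going by these compounds, is whether a hydroxyl, an amine or a carboxylic acid at this position would also leave the number within the scatter.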